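This account rests on a few compounds, and the source may have more. Where it says the series, first, only, none or still open, it means among the compounds named here.

Compound 1, `Cc1cccc(-c2nn(-c3ccc(F)cc3F)cc2CNCCN2CCN(C)CC2)c1`: in an ADME assay on Huh-7 cells (Homo sapiens) for cytotoxicity (on this read-out higher numbers stand for lower toxicity in this test and lower numbers for higher toxicity in this test), compound 1 returns > 20000 nM, which is a limit of the assay and not a measured number.
Compound 2, `Cc1ccccc1-c1nn(-c2ccc(F)c(F)c2)cc1CNCCN1CCN(C)CC1`: in this assay compound 2 returns > 20000 nM, again only a limit.
Compound 3, `CCCN1CCC(CNCc2cn(-c3ccc(F)cc3F)nc2-c2ccccc2C)CC1`: in this assay compound 3 returns > 20000 nM, once more a limit.

Compound 3 therefore stands at the top end of what this assay can report, and the other two compounds stand there with it; in other words (the limit of > 20000 nM in this assay, at which 3 of the 3 values shown sit). Among the measured compounds shown here, no pair of measured compounds differs in a single place, so no measured step exists from which the size of a structural change could be read.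

Compound 4, `Cc1ccccc1-c1nn(-c2ccc(F)cc2F)cc1CNCc1ccncc1`, differs from compound 3 in one place: pyridin-4-yl in place of 1-propylpiperidin-4-yl on a saturated chain carbon bound to an amine nitrogen. With every measured value sitting at the limit, nothing shown favours a shift in either direction. The expected step is a step that the limit leaves unreadable from compound 3 to compound 4, meaning no change beyond the usual scatter. Compound 4 is accordingly expected to give about 30000 nM, somewhere between 12000 nM and 80000 nM, and most likely again only a limit, because all three measured values sit at the limit of > 20000 nM in this assay, at which 3 of the 3 values shown sit.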

Compound 4, half-maximal cytotoxic concentration: > 20000 nM
Compound 4: a limit, no number (the forecaster's own chance of this, stated with the estimate: 80%); the middle value does not contradict the limit.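

Compound 3 and compound 4 both return only a limit in this assay, so the change from 1-propylpiperidin-4-yl to pyridin-4-yl cannot be given a size: the limit of > 20000 nM in this assay, at which 4 of the 4 values shown sit.

The compounds shown leave open at what concentration any of them would reach the half-maximal effect, and which structural change, if any, would move the read-out in this assay.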